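Thiadiazole to triazole swap on a nitrophenyl thiazole hydrazone

This account rests on a few compounds, and the source may have more. Where it says the series, first, only, none or still open, it means among the compounds named here.

Measured compounds: compound 1 `Cc1nnc(SCC(=O)N/N=c2/scc(-c3ccc(C#N)cc3)n2-c2ccccc2)s1`, in an ADME assay on NIH3T3 cells (Mus musculus) for cytotoxicity, read by MTT assay, with a stated time of 24 h (on this read-out lower numbers stand for stronger inhibition and higher numbers for weaker inhibition), compound 1 sits at the limit < 3.9 ug/mL, which is a limit of the assay and not a number. Compound 2 `Cc1nnc(SCC(=O)N/N=c2/scc(-c3ccc([N+](=O)[O-])cc3)n2-c2ccccc2)s1` gives 177 ug/mL. Compound 3 `COc1ccc(-c2cs/c(=N/NC(=O)CSc3nnc(C)s3)n2-c2ccccc2)cc1` gives 300 ug/mL.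

Compound 2 holds the lowest of the two numbers; its nearest neighbour is compound 3, a 1.7-fold higher number from compound 2 to compound 3 (0.23 log units; within the scatter). The other value, that of compound 1, is a limit (the limit of < 3.9 ug/mL in this assay, at which 1 of the 3 values shown sits).

Compound 4 `Cn1cnnc1SCC(=O)N/N=c1/scc(-c2ccc([N+](=O)[O-])cc2)n1-c1ccccc1` differs from compound 2 by 4-methyl-4H-1,2,4-triazol-3-yl in place of 5-methyl-1,3,4-thiadiazol-2-yl on a sulfur. Within the data shown here, none of the measured steps touches this sulfur-borne ring: an at least 45-fold higher number from compound 1 to compound 2 (1.65 log units; beyond the scatter) and an at least 76-fold higher number from compound 1 to compound 3 (1.88 log units; beyond the scatter) concern the aromatic substituent, and a 1.7-fold higher number from compound 2 to compound 3 (0.23 log units; within the scatter) likewise. So no step beyond the scatter is expected in this assay. Compound 4 is therefore estimated at 160 ug/mL, between 45 ug/mL and 400 ug/mL, a step of a 1.1-fold lower number from compound 2 to compound 4 (0.04 log units; within the scatter).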

Compound 4, half-maximal inhibitory concentration: 133 ug/mL
Compound 4: middle estimate off by 1.2-fold (0.08 log units), on the high side, and the stated range covers the measured number.
By their numbers in this assay, from the lowest: compounds 4, 2 and 3 (each within the scatter of the next, the first and the last beyond it). At a limit, below all of these: compound 1.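

In this assay, among these compounds, the earlier steps concerned only the aromatic substituent, whereas this one changes the ring on the sulfur: a 1.3-fold lower number from compound 2 to compound 4 (0.12 log units; within the scatter). With the nitro group kept, one five-membered aromatic ring can thus replace the other on this sulfur without a change beyond the scatter. Nothing shown here bears on the reason for this result.

Going by these compounds, whether the same swap holds on the core of compound 1 stays open. So does the outcome of placing a simple chain ending in a carboxylic acid or an amine on this sulfur.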